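This account rests on a few compounds, and the source may have more. Where it says the series, first, only, none or still open, it means among the compounds named here.

Compound 1, `CCc1cccc2cc(C(=O)O)cnc12`, in a functional assay on the whole organism (strain Sprague-Dawley) for inhibition, with Rattus norvegicus as the target (on this read-out higher numbers stand for an effect only at larger amounts of compound and lower numbers for an effect already at smaller amounts), gives > 50 mg/kg, which is a limit of the assay and not a number. Compound 2, `Fc1cccc2cc(-c3nn[nH]n3)cnc12`, in this assay gives > 10 mg/kg, again a limit. Compound 3, `Cc1cccc2cc(C(=O)O)cnc12`, in this assay gives > 50 mg/kg, also a limit.

Compound 3 therefore stands at a limit only, like the two other compounds shown: two values sit at the limit of > 50 mg/kg in this assay, at which 2 of the 3 values shown sit, and one at the limit of > 10 mg/kg in this assay, at which 1 of the 3 values shown sits. Going by the values given here, the single step between measured compounds, a step that the two limits leave unreadable from compound 1 to compound 3, is unreadable since both ends are limits.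

Compound 4, `O=C(O)c1cnc2c(F)cccc2c1`, arises from compound 3 by the change (fluoro in place of methyl on an aromatic carbon). Among the compounds with values here, no measured step bears on this exchange; compound 2 carries fluoro but differs from compound 3 in more than one place and is itself only a limit. Compound 4 is expected to show a step that the limit leaves unreadable from compound 3 to compound 4 no larger than the scatter. Compound 4 is therefore estimated at 60 mg/kg, between 20 mg/kg and 200 mg/kg, most probably again reported only as a limit.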

Compound 4, minimum effective dose: > 25 mg/kg
Compound 4: a limit, no number; the forecaster's own chance of this, stated with the estimate: 80%; the middle value is on the limit's open side.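

In this assay compound 4 gives > 25 mg/kg, a limit of the assay and not a number. The steps to compound 4 from compound 1, compound 2 and compound 3 have limits at both ends and cannot be read. The compounds shown leave open at what dose any of them would show an effect, and whether fluoro in place of methyl on an aromatic carbon changes that dose.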